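From Chloro to Bromo on a Shared Core

The source may hold more compounds than are shown below. What is called first, only, known or untested is meant among the compounds shown, and "the series" means these compounds.

Measured compounds:
compound 1, `Clc1ccc(-c2csnn2)cc1`: > 100000 nM (a limit)
compound 2, `c1csc(-c2csnn2)c1`: 66900 nM
compound 3, `c1csc(-c2c[se]nn2)c1`: "not determined" (no result reported)

In an ADME assay on MCF7 cells (Homo sapiens) for cytotoxicity, read by MTT assay, with a stated time of 48 h (on this read-out higher numbers stand for weaker inhibition and lower numbers for stronger inhibition), compound 1 gives only a limit, > 100000 nM, and no number. Compound 2 gives 66900 nM in this assay. For compound 3 the result in this assay is "not determined" (no result reported). Compound 1 therefore stands without a single number: it sits at the limit of > 100000 nM in this assay, at which 1 of the 3 values shown sits, and beside it one further entry carries no number at all. No step between two measured compounds that differ in one place is available, so nothing among these three tells how a single change moves the read-out.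

Compound 4, `Brc1ccc(-c2csnn2)cc1`, differs from compound 1 in one place: bromo in place of chloro on an aromatic carbon. The accompanying account sits with the change itself. For the measured compounds named here, with no measured step to lean on, the expectation for this assay is a step of no size beyond the usual scatter in either direction. Compound 4 is expected to give 120000 nM in this assay, with a range from 50000 nM to 300000 nM. The expected step that the limit leaves unreadable from compound 1 to compound 4 is small, and because compound 1 rests at the limit of > 100000 nM in this assay, at which 1 of the 3 values shown sits, a limit rather than a number is again the most likely outcome for compound 4.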

Compound 4, half-maximal inhibitory concentration: 68100 nM
The estimate for compound 4 lay 1.8-fold (0.25 log units) above the measured number; measured number inside the range.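

With bromo in place of chloro on an aromatic carbon, para to a group of 5 heavy atoms, compound 4 gives 68100 nM in this assay and so puts a single number on this shared core, which the chloro compound did not provide. The change gives an at least 1.4-fold lower number from compound 1 to compound 4 (0.16 log units; that floor lies within the scatter) and so fixes only a floor on the size of the step, not the step itself, and that floor alone does not set the two compounds apart. Compound 1 remains a limit and not a number: the limit of > 100000 nM in this assay, at which 1 of the 4 values shown sits.

The compounds shown leave open how far the read-out would move if an amine, a carboxylic acid or a longer chain stood at this position on the six-membered ring instead of either halogen. They also leave open the true distance between the chloro and bromo compounds, which can only be stated once the chloro compound has a number of its own rather than a limit.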